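Adding a Chloro Group to Compound 2

This account rests on a few compounds, and the source may have more. Where it says the series, first, only, none or still open, it means among the compounds named here.

Compound 1 `Cc1ccc(C)c(NS(=O)(=O)c2cccc(CCCCCCNC(=O)/C=C/c3cccnc3)c2)c1`: 22.6 nM
Compound 2 `O=C(/C=C/c1cccnc1)NCCCCCCc1cccc(S(=O)(=O)Nc2ccc(F)cc2)c1`: 99.9 nM

Going by the values given here, in a functional assay on HeLa cells (Homo sapiens) for inhibition, read by CCK-8 assay, with a stated time of 72 h (on this read-out lower numbers stand for stronger inhibition and higher numbers for weaker inhibition), compound 2 gives 99.9 nM, the higher of the two numbers so far. Compound 3 `O=C(/C=C/c1cccnc1)NCCCCCCc1cccc(S(=O)(=O)Nc2ccc(F)c(Cl)c2)c1` differs from it in one place: chloro in place of hydrogen on an aromatic carbon. This is chloro in place of hydrogen on an aromatic carbon, ortho to a fluoro group. Among the compounds with values here, the one measured step that bears on this is a 4.4-fold higher number from compound 1 to compound 2 (0.65 log units; beyond the scatter), with 4-fluorophenyl replacing 2,5-dimethylphenyl on a sulfonamide nitrogen. It shows that this group can shift the number, so a smaller, downward change is expected here. The expected change is a 1.8-fold lower number from compound 2 to compound 3 (0.26 log units; within the scatter). The estimate for compound 3 is 55 nM, with an expected range of 22 nM to 130 nM.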

Compound 3, half-maximal inhibitory concentration: 385 nM
Beside the measured number, compound 3's estimate is 7.0-fold (0.85 log units) below it, outside the stated range (above it).
By their numbers in this assay, from the lowest: compound 1; then compound 2; then compound 3.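

In this assay, chloro on the aromatic carbon ortho to the fluoro group gives a 3.9-fold higher number from compound 2 to compound 3 (0.59 log units; beyond the scatter) and so weakens inhibition, which shows that this ring position does not tolerate every change. Set against the 2,5-dimethylphenyl group, the 3-chloro-4-fluorophenyl group gives a 17-fold higher number from compound 1 to compound 3 (1.23 log units; beyond the scatter) and makes this the largest step so far. Nothing available explains this rise.

As far as these compounds go, whether a methyl or methoxy group at this place would raise the number as well stays open. So does whether chloro would do so without the fluoro group.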